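From 4-hydroxyphenyl to 4-methylphenyl: an expected step

The source may report more compounds than this note shows. Statements on the series, on what has been measured and on what is new or still open speak of the compounds shown alone.

Among the measured compounds shown here, in a functional assay on HCT-8 cells (Homo sapiens) for cytotoxicity (on this read-out higher numbers stand for an effect only at larger amounts of compound and lower numbers for an effect already at smaller amounts), compound 2 (`COC1=C(C)C(=O)/C(=C(O)/C=C/c2ccc(O)cc2)C(=O)C1(C)C`) gives 14.8 ug/mL as the highest of the two numbers so far, while compound 1 (`COC1=C(C)C(=O)/C(=C(O)/C=C/c2cccc(OC)c2)C(=O)C1(C)C`) gives 2.9 ug/mL as the lower one. Compound 3 (`COC1=C(C)C(=O)/C(=C(O)/C=C/c2ccc(C)cc2)C(=O)C1(C)C`) has not yet been measured. It carries methyl in place of hydroxy on an aromatic carbon, para to a large group (methyl in place of hydroxy on an aromatic carbon), so 4-hydroxyphenyl becomes 4-methylphenyl. For the measured compounds named here, only one measured step bears on this change, and only indirectly, since it starts from 3-methoxyphenyl: a 5.1-fold higher number from compound 1 to compound 2 (0.71 log units; beyond the scatter) in this assay is the sole guide. Compound 3 gives up the 4-hydroxyphenyl group that only compound 2 carries, so a move toward compound 1 is expected, though probably not all the way. The expected change is a 2.5-fold lower number from compound 2 to compound 3 (0.39 log units; beyond the scatter) as a cautious estimate. For compound 3 the estimated value is 6 ug/mL with 2.2 ug/mL to 14 ug/mL as the expected range.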

Compound 3, concentration for half-maximal effect: 4.1 ug/mL
Compound 3: middle estimate off by 1.5-fold (0.17 log units), on the high side; the range from low to high includes it.
By their numbers in this assay, from the lowest: compounds 1 and 3 (each within the scatter of the next); then compound 2.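

In this assay, exchanging hydroxy for methyl on an aromatic carbon, para to a large group, gives a 3.6-fold lower number from compound 2 to compound 3 (0.56 log units; beyond the scatter) and ties the higher number of compound 2 to the hydroxy group itself, which the earlier step could not do, as it changed both the group and its place on the phenyl ring. The step of a 1.4-fold higher number from compound 1 to compound 3 (0.15 log units; within the scatter) cannot separate 4-methylphenyl from 3-methoxyphenyl, so of the three phenyl groups only 4-hydroxyphenyl stands apart in this set. No measurement here gives a reason for the effect of this exchange.

From the compounds shown here alone, whether the higher number is peculiar to hydroxy or would also appear with an amine or a carboxylic acid on the same aromatic carbon remains open. The compounds shown also leave open how hydroxy would behave in the place that methoxy holds in compound 1.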